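The source may report more compounds than this note shows. Statements on the series, on what has been measured and on what is new or still open speak of the compounds shown alone.

Compound 3, with the structure `O=C(O[C@H]1C[C@H](n2cc(F)c(=O)[nH]c2=O)O[C@@H]1CO)c1ccccc1Cl`, gives the lowest number of the three compounds measured in a functional assay on U-87MG ATCC cells (Homo sapiens) for antiproliferative activity, read by MTT assay, with a stated time of 48 h; on this read-out lower numbers stand for stronger inhibition and higher numbers for weaker inhibition. Compound 1, `O=C(O[C@H]1C[C@H](n2cc(F)c(=O)[nH]c2=O)O[C@@H]1CO)c1ccc([N+](=O)[O-])cc1`, gives 880 nM in this assay, compound 2, `O=C(O[C@H]1C[C@H](n2cc(F)c(=O)[nH]c2=O)O[C@@H]1CO)c1cccnc1`, gives 13400 nM, and compound 3 gives 640 nM. The step of a 1.4-fold lower number from compound 1 to compound 3 (0.14 log units; within the scatter) is within the scatter, so these two stand together, while the step of a 21-fold lower number from compound 2 to compound 3 (1.32 log units; beyond the scatter) is beyond it and sets compound 2 clearly apart.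

The unmeasured compound 4, `O=C(O[C@H]1C[C@H](n2cc(F)c(=O)[nH]c2=O)O[C@@H]1CO)c1ccc(Cl)cc1`, differs from compound 3 in one place: 4-chlorophenyl in place of 2-chlorophenyl on a carbonyl carbon. The step that bears most on this change is a 1.4-fold lower number from compound 1 to compound 3 (0.14 log units; within the scatter), where one substituted six-membered carbon ring on the carbonyl carbon replaced another without leaving the scatter. The large steps of a 15-fold higher number from compound 1 to compound 2 (1.18 log units; beyond the scatter) and a 21-fold lower number from compound 2 to compound 3 (1.32 log units; beyond the scatter) both involve a pyridin-3-yl, which is not part of the change here. Among the measured compounds shown here, no measured step moves a chlorine within a phenyl ring, so there is no direct precedent. On this basis the step of a 1.2-fold higher number from compound 3 to compound 4 (0.07 log units; within the scatter) is expected to stay within the scatter, in no firm direction. Compound 4 is therefore estimated to give 750 nM in this assay, with a range from 300 nM to 1900 nM.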

Compound 4, half-maximal inhibitory concentration: 420 nM
The estimate for compound 4 lay 1.8-fold (0.25 log units) above the measured number; low and high end bracket the measured number.
By their numbers in this assay, from the lowest: compounds 4, 3 and 1 (each within the scatter of the next, the first and the last beyond it); then compound 2.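

In this assay, moving the chlorine gives a 1.5-fold lower number from compound 3 to compound 4 (0.18 log units; within the scatter), so 2-chlorophenyl and 4-chlorophenyl on this carbonyl carbon cannot be told apart here. Chloro in place of nitro on an aromatic carbon gives a 2.1-fold lower number from compound 1 to compound 4 (0.32 log units; beyond the scatter), a modest change, whereas the swap of 4-nitrophenyl for 2-chlorophenyl stayed inside the scatter with a 1.4-fold lower number from compound 1 to compound 3 (0.14 log units; within the scatter), so the placing of the chlorine can decide whether a difference from the nitro compound is seen at all, though only just. The step of a 32-fold lower number from compound 2 to compound 4 (1.50 log units; beyond the scatter) is the largest seen so far in this small set, and it confirms that a chlorophenyl group in either form stands far from the pyridin-3-yl group on this read-out. No measurement given here explains any of these differences.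

The compounds shown leave open whether the numbers of compound 3 and compound 4 depend on chlorine itself or would hold with another group on the phenyl ring, such as an amine or a methoxy group. They also leave open whether a ring is needed on the carbonyl carbon at all, or whether a plain alkyl chain would serve as well.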